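This account rests on a few compounds, and the source may have more. Where it says the series, first, only, none or still open, it means among the compounds named here.

Working notes on the series. In a functional assay on HEK293 cells for activation of 5-hydroxytryptamine receptor 4 (Homo sapiens), read by cAMP accumulation (on this read-out higher numbers stand for larger maximal responses and lower numbers for smaller maximal responses), compound 1 `COc1cc(N)c(Cl)cc1C(=O)NCCN1CCNCC1` reaches a limit of the assay, > 100%. Compound 2 `CC(C)n1c(=O)n(C(=O)NCC2CCNCC2)c2ccccc21` gives 92% in this assay. Compound 3 `CCN1CCC(NC(=O)c2cc(Cl)c(N)cc2OC)CC1` also reports only a limit of the assay in this assay, > 100%. Where compound 3 stands on the numbers shown is therefore not a number but a limit, and the same holds for one of the other two values: the limit of > 100% in this assay, at which 2 of the 3 values shown sit. Going by the values given here, no step between measured compounds that differ in one place is available, so nothing in the measured set tells how large an effect a single change produces here.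

The next compound to be run is compound 4 `COc1cc(N)c(Cl)cc1C(=O)NC1CCN(CCN2CCN(S(C)(=O)=O)CC2)CC1`. It differs from compound 3 by 4-(methylsulfonyl)piperazin-1-yl in place of hydrogen on a saturated chain carbon, two bonds along the chain from an amine nitrogen in a ring. The shared core of compound 3 and compound 4 is kept; the change is confined to the saturated chain carbon named above.

Among the compounds with values here, with no measured step to lean on, the expected step of a number no higher from compound 3 to compound 4 (the limit leaves the size open) in this assay is taken as none beyond the usual scatter, since compound 3 already sits at the limit > 100% and both related compounds with this core reach it as well. Compound 4 is estimated at 100% in this assay, within 85% to 115%, with a fair chance that only a limit is reported.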

Compound 4, intrinsic activity: the largest response reached, in percent of the reference agonist's: 97%
Beside the measured number, compound 4's estimate is 3 percentage points above it; measured number inside the range.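

In this assay, going by these compounds alone, 4-(methylsulfonyl)piperazin-1-yl in place of hydrogen on a saturated chain carbon, two bonds along the chain from an amine nitrogen in a ring, gives the first step between compounds that differ in one place: a number at least 3 percentage points lower from compound 3 to compound 4 (that floor lies within the scatter). Compound 4 carries 10 heavy atoms more at this position and its own six-membered non-aromatic ring, yet gives 97% as a number rather than a limit, so a substituent of this size at this carbon is compatible with a large maximal response on this read-out. Going by these compounds, the true size of the step remains unknown because the value of compound 3 is only a limit: the limit of > 100% in this assay, at which 2 of the 4 values shown sit.

It stays open whether the methylsulfonyl group contributes to this response or whether the size of the substituent plays any part, as the compounds shown hold only one substituent at this carbon. A plain piperazin-1-yl group, a morpholine ring or a longer chain at the same carbon would begin to separate these parts, and the maximal responses shown say nothing about the concentrations needed to reach them.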